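The compounds below may be only part of what the source reports. "The series", "measured", "known", "first", "only" and "open" are said of these compounds alone.

Of the compounds shown here, two built on the shared core have been read in a functional assay on HeLa cells (Homo sapiens) for cytotoxicity, read by MTT assay, with a stated time of 2 days; a higher number here means a weaker inhibitor, a lower number a stronger inhibitor. Compound 1 `Cc1cccc(-c2nc3cc(C)ccc3c(=O)[nH]2)c1` gives 11200 nM in this assay. Compound 2 `Cc1ccc2c(=O)[nH]c(-c3ccccc3C)nc2c1` reaches only the limit of this assay, > 50000 nM, so no number is known for it. This is where compound 2 stands among the values shown: at the limit, as noted in the limit of > 50000 nM in this assay, at which 1 of the 2 values shown sits, while compound 1 has a number.

Compound 3 `Cc1ccc2c(=O)[nH]c(-c3ccccc3OC(F)(F)F)nc2c1` has not yet been measured in this assay. It differs from compound 2 in one place: trifluoromethoxy in place of methyl on an aromatic carbon. Among the compounds with values here, no step between two measured compounds that differ in one place is available, so the data give no measured size for such a change in this assay. Without that, no step beyond the usual scatter is expected from compound 2 to compound 3, and the estimated step is a number no higher from compound 2 to compound 3 (the limit leaves the size open). Compound 3 is accordingly expected near the limit in this assay, estimated at 50000 nM, with a range from 15000 nM to 100000 nM, and a considerable chance that only a limit is reported again.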

Compound 3, half-maximal inhibitory concentration: 18300 nM
Compound 3: the middle estimate sits 2.7-fold (0.44 log units) above what was measured, and the stated range covers the measured number.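

In this assay, within the data shown here, the change at this place, on an aromatic carbon ortho to a large group, gives the first step that can be read: trifluoromethoxy in place of methyl gives an at least 2.7-fold lower number from compound 2 to compound 3 (0.43 log units; beyond the scatter). The step shows that the group at this place can move a compound off the limit of the assay, since compound 3 has a true number. Compound 3 gives 18300 nM. The step is only a lower bound, because the value of compound 2 is a limit and not a number, which leaves the true size open: the limit of > 50000 nM in this assay, at which 1 of the 3 values shown sits.

With a single pair at this place, the compounds shown do not tell whether the step belongs to the oxygen or to the fluorines of the new group, a question that methoxy and trifluoromethyl at the same carbon would separate, and they give no reading for an amine or a carboxylic acid there. On these data alone, whether the same exchange gives a step of similar size at another place on this ring, or with the methyl on the shared core replaced, also remains open.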